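The source may report more compounds than this note shows. Statements on the series, on what has been measured and on what is new or still open speak of the compounds shown alone.

Working notes on the series. Compound 1 `O=C(/C=C/c1ccccc1Cl)c1ccc(OCc2ccccc2)cc1`, compound 2 `O=C(/C=C/c1ccc(F)cc1)c1ccc(OCc2ccccc2)cc1` and compound 3 `Cc1ccc(COc2ccc(C(=O)/C=C/c3ccc(F)cc3)cc2)cc1` have been run in a functional assay on CAL-51 cells (Homo sapiens) for inhibition, read by sulforhodamine B assay, with a stated time of 3 days; a lower number here means a stronger inhibitor of growth, a higher number a weaker inhibitor of growth. Compound 1 gives 7100 nM in this assay. For compound 2 this assay reports only a limit, > 50000 nM, not a number. For compound 3 this assay likewise reports only a limit, > 50000 nM. Within the data shown here, the one readable step is an at least 7.0-fold higher number from compound 1 to compound 2 (0.84 log units; beyond the scatter). Compound 2 thus stands at the limit of > 50000 nM in this assay, at which 2 of the 3 values shown sit, and since compound 3 sits there too, a step that the two limits leave unreadable from compound 2 to compound 3. Compound 4 `O=C(/C=C/c1ccccc1)c1ccc(OCc2ccccc2)cc1` is not yet measured; it differs from compound 2 by hydrogen in place of fluoro on an aromatic carbon. Among the measured compounds shown here, of the measured steps only the one from compound 1 to compound 2 touches the phenyl on the double-bonded chain carbon, and there the exchange of one halogenated phenyl for another read at least modest, with the limit hiding its true size. Removing fluoro gives no firm direction. The expected step is an at least 1.2-fold lower number from compound 2 to compound 4 (0.09 log units; that floor lies within the scatter), essentially none beyond the scatter. The estimate for compound 4 is 40000 nM, with a range from 10000 nM to 80000 nM, and a fair chance that this assay again reports only a limit.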

Compound 4, concentration for 50% growth inhibition: 28900 nM
Estimate against measurement, compound 4: 1.4-fold (0.14 log units) above; low and high end bracket the measured number.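

With compound 4, the plain phenyl on the chain gains a measured reference in this assay, so the earlier exchange of one halogenated phenyl for another separates into two single changes. Hydrogen in place of chloro gives a 4.1-fold higher number from compound 1 to compound 4 (0.61 log units; beyond the scatter), which shows that chloro on this phenyl matters in compound 1, whereas hydrogen in place of fluoro gives an at least 1.7-fold lower number from compound 2 to compound 4 (0.23 log units; that floor lies within the scatter), so no effect of fluoro is established beyond the scatter. Compound 2 remains a limit and not a number: the limit of > 50000 nM in this assay, at which 2 of the 4 values shown sit.

The compounds shown leave open whether the difference follows chloro itself or its place on the ring, a question that a 4-chlorophenyl analogue would address directly. Also open, going by these compounds, is whether a methoxy group or an amine on this phenyl would give a lower number than compound 1 does.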